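Aryl swap on the sulfonyl of compound 3

A few compounds are considered here, and "the series" means these few. Any claim that something is new, unique, unknown or untested is made for them only; others in the source may bear on it.

The series shares one core, carried in compound 1 `O=c1cc(Cn2cc(CCCCl)nn2)c2ccc(O)cc2o1`, compound 2 `CC(O)c1cn(Cc2cc(=O)oc3cc(O)ccc23)nn1` and compound 3 `O=c1cc(Cn2cc(CNS(=O)(=O)c3ccc(Cl)cc3)nn2)c2ccc(O)cc2o1`. In a functional assay on HepG2 cells (Homo sapiens) for inhibition, read by MTT assay, with a stated time of 72 h (a lower number here means a stronger inhibitor, a higher number a weaker inhibitor), compound 1 reports only a limit, > 100000 nM. Compound 2 likewise gives a limit in this assay, > 100000 nM. The step that the two limits leave unreadable from compound 1 to compound 2 therefore cannot be read. Among the measured compounds shown here, compound 3 is the only member with a number, 31400 nM in this assay. Two of the three values shown sit at the limit of > 100000 nM in this assay, at which 2 of the 3 values shown sit. Compound 4 `O=c1cc(Cn2cc(CNS(=O)(=O)c3ccc(F)cc3Cl)nn2)c2ccc(O)cc2o1` differs from compound 3 by 2-chloro-4-fluorophenyl in place of 4-chlorophenyl on a sulfonyl sulfur. For the measured compounds named here, no measured step touches the group on the sulfonyl sulfur, so nothing here sizes this change. Compound 4 is expected to stay near compound 3, a step of a 1.0-fold lower number from compound 3 to compound 4 (0.02 log units; within the scatter) within the scatter. The estimate for compound 4 is 30000 nM, between 10000 nM and 100000 nM.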

Compound 4, half-maximal inhibitory concentration: 74800 nM
For compound 4 the middle estimate is 2.5-fold (0.40 log units) below the measured one; the range from low to high includes it.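

In this assay the group on the sulfonyl sulfur is not silent: 2-chloro-4-fluorophenyl in place of 4-chlorophenyl gives a 2.4-fold higher number from compound 3 to compound 4 (0.38 log units; beyond the scatter). Among the compounds shown here, this is the first readable step and it runs towards a weaker inhibitor, so this position can be sized, at least for this one change.

For the compounds shown here, the single swap does not separate the chlorine from the fluorine of 2-chloro-4-fluorophenyl, and how a phenyl carrying a carboxylic acid or an amine would read on the sulfonyl sulfur stays open. Nothing measured in the compounds shown accounts for the step.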